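Swapping Methoxy for a Sulfonamide: Expected Loss of Stability

The source may hold more compounds than are shown below. What is called first, only, known or untested is meant among the compounds shown, and "the series" means these compounds.

Compound 3 `COc1cc(C2CCN(CC(N)=O)CC2)ccc1Nc1ncc2ccc(-c3ccccc3OC)n2n1` carries a methoxy group, and in an in vitro ADME assay on microsomes from liver (Homo sapiens) for metabolic stability, using NADPH, with a stated time of 10 min, tested at 0.5 uM (a lower number here means that the compound disappears faster, a higher number that the compound lasts longer), compound 3 reaches > 0.666 h, which is a limit of the assay rather than a number. Compound 4 `COc1cc(C2CCN(CC(N)=O)CC2)ccc1Nc1ncc2ccc(-c3ccccc3N(C)S(C)(=O)=O)n2n1` differs from it by methyl(methylsulfonyl)amino in place of methoxy on an aromatic carbon. Among the compounds with values here, no measured pair isolates this change. Compound 1 `COc1cc(C2CCN(C[C@@H](C)O)CC2)ccc1Nc1ncc2ccc(-c3ccccc3N(C)S(C)(=O)=O)n2n1`, which already carries the methyl(methylsulfonyl)amino group, gives < 0.0834 h in this assay, again a limit rather than a number. Within the data shown here, compound 2 `COc1cc(C2CCNCC2)ccc1Nc1ncc2ccc(-c3ccccc3N(C)S(C)(=O)=O)n2n1` gives 0.117 h, and the one measured step, an at least 1.4-fold higher number from compound 1 to compound 2 (0.14 log units; that floor lies within the scatter), alters only the amine substituent and stays within the scatter. Because compound 2 gives 0.117 h with the same sulfonamide, compound 4 is expected to reach only 0.15 h, between 0.06 h and 0.4 h. The expected change is an at least 4.4-fold lower number from compound 3 to compound 4 (0.64 log units; beyond the scatter).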

Compound 4, half-life: < 0.0834 h
Compound 4: a limit, no number; the forecaster's own chance of this, stated with the estimate: 30%; middle value at least 1.7-fold (0.25 log units) away from the limit.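

In this assay, the methyl(methylsulfonyl)amino group in place of methoxy on this aromatic carbon gives an at least 7.9-fold lower number from compound 3 to compound 4 (0.90 log units; beyond the scatter), so this change now has a measured pair that isolates it, and the loss is clear even as a floor. Carbamoylmethyl in place of hydrogen on the ring amine nitrogen gives an at least 1.4-fold lower number from compound 2 to compound 4 (0.14 log units; that floor lies within the scatter), which shows no clear change. The pair of compound 1 and compound 4 cannot be read, since both values sit at the same limit: the limit of < 0.0834 h in this assay, at which 2 of the 4 values shown sit.

On these data alone, the full size of the drop stays open: only a floor is available. Also open, as far as these compounds go, is whether an amine or a chlorine on this aromatic carbon would behave like methoxy or like the sulfonamide group.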